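The source may hold more compounds than are shown below. What is called first, only, known or untested is meant among the compounds shown, and "the series" means these compounds.

Compounds measured in a functional assay on MV4-11 cells (Homo sapiens) for antiproliferative activity, read by CellTiter-Glo, with a stated time of 72 h; a lower number here means a stronger inhibitor, a higher number a weaker inhibitor:
compound 1, `COc1ccc2[nH]cc(-c3cnc(N(C)[C@@H]4C[C@H]5O[C@@](C)([C@@H]4OC)n4c6ccccc6c6c7c(c8c9cc(Cl)ccc9n5c8c64)C(=O)NC7)s3)c2c1`: 440 nM
compound 2, `CO[C@@H]1[C@H](N(C)c2ncc(-c3c[nH]c4ccccc34)s2)C[C@H]2O[C@]1(C)n1c3ccccc3c3c4c(c5c6cc(Br)ccc6n2c5c31)C(=O)NC4`: 360 nM
compound 3, `CO[C@@H]1[C@H](N(C)c2ncc(-c3c[nH]c4ccc(F)cc34)s2)C[C@H]2O[C@]1(C)n1c3ccccc3c3c4c(c5c6cc(Br)ccc6n2c5c31)C(=O)NC4`: 960 nM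

Compound 3 carries the highest number of the three; the nearest is compound 1 and the furthest compound 2, and both gaps lie beyond the scatter. Going by the values given here, the only single change that can be followed is a 2.7-fold higher number from compound 2 to compound 3 (0.43 log units; beyond the scatter), where fluoro replaces hydrogen. Compound 4, `COc1ccc2[nH]cc(-c3cnc(N(C)[C@@H]4C[C@H]5O[C@@](C)([C@@H]4OC)n4c6ccccc6c6c7c(c8c9cc(Br)ccc9n5c8c64)C(=O)NC7)s3)c2c1`, arises from compound 3 by methoxy in place of fluoro on an aromatic carbon. Among the compounds with values here, no measured step exchanges fluoro for methoxy directly. Compound 1, which carries methoxy in that place but chloro rather than bromo on the shared core, and compound 2, which carries hydrogen there, give numbers within the scatter of each other, so methoxy seems to behave much like hydrogen here. Compound 4 is therefore expected to give a lower number than compound 3, roughly undoing the loss that fluoro brought, an estimated 2.3-fold lower number from compound 3 to compound 4 (0.36 log units; beyond the scatter). The estimate for compound 4 in this assay is 420 nM, with a range from 200 nM to 900 nM.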

Compound 4, half-maximal inhibitory concentration: 510 nM
Compound 4: the middle estimate sits 1.2-fold (0.08 log units) below what was measured; the range from low to high includes it.
By their numbers in this assay, from the lowest: compounds 2, 1, 4 and 3 (each within the scatter of the next, the first and the last beyond it).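

In this assay, with bromo held on the shared core, methoxy can now be set directly against both other groups at this place: against fluoro (a 1.9-fold lower number from compound 3 to compound 4 (0.27 log units; within the scatter)) and against hydrogen (a 1.4-fold higher number from compound 2 to compound 4 (0.15 log units; within the scatter)). Neither step separates the compounds, so methoxy cannot be told apart from fluoro or from hydrogen here, even though fluoro and hydrogen do differ beyond the scatter. The exchange on the core, with methoxy kept in place, also stays within the scatter (a 1.2-fold higher number from compound 1 to compound 4 (0.06 log units; within the scatter)), and no supporting evidence bears on these results.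

The compounds shown carry only hydrogen, fluoro and methoxy at this place, so the effect of a hydroxyl group, an amine or a longer alkoxy chain there remains open. Going by these compounds alone, the core exchange is seen only with methoxy at this place, and whether it would read the same with hydrogen or fluoro there also stays open.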